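Chlorophenyl in place of cyanophenyl: tolerated concentration expected

The source may report more compounds than this note shows. Statements on the series, on what has been measured and on what is new or still open speak of the compounds shown alone.

Compound 1 `Cn1c(-c2cccc([N+](=O)[O-])c2)cnc1NC(=O)c1ccc(F)cc1` gives only a limit in a toxicity assay on THP-1 cells (Homo sapiens) for inhibition (a higher number here means that more compound is tolerated, a lower number that less compound is tolerated), > 50000 nM.
Compound 2 `Cn1c(-c2cccc(C#N)c2)cnc1NC(=O)c1ccc(F)cc1` gives only a limit in this assay, > 100000 nM.
Compound 3 `Cn1c(-c2cccc(C#N)c2)cnc1NC(=O)c1ncc[nH]1` gives only a limit in this assay, > 50000 nM.

Compound 2 thus stands at a limit, as do the other two values. The two measured steps, a step that the two limits leave unreadable from compound 1 to compound 2 and a step that the two limits leave unreadable from compound 2 to compound 3, are both unreadable in size, since each joins two limits (the limit of > 100000 nM in this assay, at which 1 of the 3 values shown sits, (the limit of > 50000 nM in this assay, at which 2 of the 3 values shown sit)). Compound 4 `Cn1c(-c2ccc(Cl)cc2)cnc1NC(=O)c1ccc(F)cc1` carries the change (4-chlorophenyl in place of 3-cyanophenyl on an aromatic carbon). No readable step bears on this change, so nothing measured points to a shift in this assay beyond the scatter. Compound 4 is therefore expected to sit near a limit again, at 100000 nM (range 30000 nM to 300000 nM). The expected step is a number no higher from compound 2 to compound 4 (the limit leaves the size open).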

Compound 4, half-maximal cytotoxic concentration: 37000 nM
Estimate against measurement, compound 4: 2.7-fold (0.43 log units) above; low and high end bracket the measured number.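

In this assay, among these compounds, compound 4 is the first compound here to give a number rather than a limit, and 4-chlorophenyl in place of 3-cyanophenyl on this aromatic carbon brings an at least 2.7-fold lower number from compound 2 to compound 4 (0.43 log units; beyond the scatter). Among the compounds shown here, this makes it the first change seen to lower the tolerated concentration, though the size is only a minimum. The earlier steps shown here cannot be read, and compound 2 itself stands at a limit: the limit of > 100000 nM in this assay, at which 1 of the 4 values shown sits.

The change alters both the substituent and its place on the phenyl ring, and the compounds shown do not separate the two. On these data alone, how 3-chlorophenyl or 4-aminophenyl would fare on the same carbon remains open.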